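This account rests on a few compounds, and the source may have more. Where it says the series, first, only, none or still open, it means among the compounds named here.

Of the compounds shown here, three from this series have been tested in a functional assay on HL-60 cells (Homo sapiens) for antiproliferative activity, read by MTT assay, with a stated time of 72 h; on this read-out higher numbers stand for weaker inhibition and lower numbers for stronger inhibition. Compound 1 `NC1=NC2(CCSCC2)N(OCCCOc2ccccc2Br)C(N)=N1` gives 180 nM. Compound 3 `NC1=NC2(CCSCC2)N(OCCCOc2ccccc2Cl)C(N)=N1` differs from compound 1 in one place, (chloro in place of bromo on an aromatic carbon); in this assay compound 3 gives 390 nM. The step is a 2.2-fold higher number from compound 1 to compound 3 (0.34 log units; beyond the scatter). Compound 2 `NC1=NC2(CCOCC2)N(OCCCOc2cccc(Br)c2)C(N)=N1` carries a different core, and the difference between its core and that of compound 1 is not broken down here; compound 2 gives 560 nM.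

Compound 4 `NC1=NC2(CCOCC2)N(OCCCOc2cccc(Cl)c2)C(N)=N1` has not yet been tested in this assay. It stands to compound 2 as compound 3 stands to compound 1: the change is chloro in place of bromo on an aromatic carbon. This is the same kind of change as before, but not the same one, since in the pair from compound 1 to compound 3 the halogen sits ortho to a large group, whereas here it sits meta to a large group. The cores of the two pairs also differ, so the earlier step is only a guide.

The expectation for compound 4 in this assay is a step of a 1.8-fold higher number from compound 2 to compound 4 (0.25 log units; within the scatter), a little smaller than the one seen, because the single shown step of this kind is a 2.2-fold higher number from compound 1 to compound 3 (0.34 log units; beyond the scatter) while the change here sits in a different place. Compound 4 is therefore expected to give about 1000 nM, most likely between 450 nM and 2500 nM.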

Compound 4, half-maximal inhibitory concentration: 520 nM
Beside the measured number, compound 4's estimate is 1.9-fold (0.28 log units) above it, within the range that was stated.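

In this assay, the step for chloro in place of bromo on the core of compound 2 is a 1.1-fold lower number from compound 2 to compound 4 (0.03 log units; within the scatter), so on this core the swap leaves no change that can be told apart from repeat-to-repeat noise. On the core of compound 1, the same kind of swap gave a step beyond the scatter, yet the two steps cannot be called different from each other: the same change on two cores in this assay, a 2.2-fold higher number (0.34 log units; beyond the scatter) from compound 1 to compound 3 and a 1.1-fold lower number (0.03 log units; within the scatter) from compound 2 to compound 4, 2.3-fold (0.37 log units) apart, within the scatter of two such steps. This agreement is weak support for carrying the change from one core to the other, and it does not prove that the change behaves alike on both, since two pairs are few and they differ both in the core and in where the halogen sits on the aromatic ring.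

No pair shown keeps the halogen in one place while changing only the core, so the role of the core and the role of the halogen's place remain unseparated. Also open, going by these compounds, is how the same aromatic position would read with a methoxy group, a nitrile or an amine instead of a halogen, and how either core would respond to a longer chain linking it to the phenoxy group.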